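The source may report more compounds than this note shows. Statements on the series, on what has been measured and on what is new or still open speak of the compounds shown alone.

Measured so far:
- compound 1, `COc1ccc(Cl)cc1C(=O)Nc1ccc(C2=NN(C)C(c3ccccc3[N+](=O)[O-])C2)cc1` — 96.5%
- compound 2, `COc1ccc(Cl)cc1C(=O)Nc1ccc(C2=NN(c3ccccc3)C(c3ccccc3[N+](=O)[O-])C2)cc1` — 80.2%
- compound 3, `COc1ccc(C2CC(c3ccc(NC(=O)c4cc(Cl)ccc4OC)cc3)=NN2)cc1` — 82.6%

All three numbers come from a functional assay on the whole organism (strain albino) with Rattus norvegicus as the target, read by paw edema, with stated times of 1 h and 4 h, at a dose of 25 mg/kg by the oral route; a higher number here means a stronger effect of the compound at the dose given, a lower number a weaker effect. Compound 3 stands second highest of the three. Its nearest neighbour is compound 2, whose value lies within the scatter of that of compound 3; the furthest is compound 1, which lies beyond the scatter above compound 3.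

Going by the values given here, the only step between measured compounds that differ in one place is a number 16.3 percentage points lower from compound 1 to compound 2 (beyond the scatter), a change on the ring nitrogen. It does not touch the saturated ring carbon and so does not bear directly on the change now in question.

Compound 4 is `COc1ccc(Cl)cc1C(=O)Nc1ccc(C2=NNC(c3ccccc3[N+](=O)[O-])C2)cc1`. Its structure differs from that of compound 3 as follows: 2-nitrophenyl in place of 4-methoxyphenyl on a saturated ring carbon. Compound 4 thus carries the 2-nitrophenyl found in compounds 1 and 2, together with the unsubstituted ring nitrogen of compound 3. Among the compounds with values here, no measured pair isolates this exchange. Compounds 1 and 2, both with 2-nitrophenyl, give values that bracket the value of compound 3, so no step beyond the scatter is expected in this assay for compound 4; at most a modest rise toward compound 1 is plausible.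

The estimate for compound 4 in this assay is 88%, with a range from 76% to 98%; the expected step is a number 5.4 percentage points higher from compound 3 to compound 4 (within the scatter).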

Compound 4, a percentage reported as activity, at one dose (the size of the read-out at that dose, not a potency): 88.3%
The estimate for compound 4 lay 0.3 percentage points below the measured number; the range from low to high includes it.
By their numbers in this assay, from the lowest: compounds 2, 3, 4 and 1 (each within the scatter of the next, the first and the last beyond it).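

In this assay, going by these compounds alone, the exchange of 4-methoxyphenyl for 2-nitrophenyl on the saturated ring carbon gives a number 5.7 percentage points higher from compound 3 to compound 4 (within the scatter) and is the first direct reading of this place, and at this one dose it does not tell the two groups apart. With 2-nitrophenyl held fixed, hydrogen in place of phenyl on the ring nitrogen gives a number 8.1 percentage points higher from compound 2 to compound 4 (within the scatter) and hydrogen in place of methyl gives a number 8.2 percentage points lower from compound 1 to compound 4 (within the scatter), so the compound with the unsubstituted nitrogen falls within the scatter of both substituted compounds, even though methyl and phenyl themselves are separated by a number 16.3 percentage points lower from compound 1 to compound 2 (beyond the scatter) in the same series. Nothing at hand explains any of these steps.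

Within the data shown here, only two aryl groups have been compared on the saturated ring carbon, so the reading of an aminophenyl or a carboxyphenyl group there remains open, as does that of an acetyl group or a longer alkyl chain on the ring nitrogen. From the compounds shown here alone, whether methyl on the ring nitrogen would give the same step with 4-methoxyphenyl in place of 2-nitrophenyl also remains open, and a read-out at one dose shows only a stronger or weaker effect at that dose, so how these compounds would compare at other doses is unsettled.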